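Replacing the cyanophenyl arm with a short chain

A few compounds are considered here, and "the series" means these few. Any claim that something is new, unique, unknown or untested is made for them only; others in the source may bear on it.

Measured so far:
compound 1, `Nc1nc(O)c2c(n1)n(C1OC(CO)[C@@H](O)[C@H]1O)c(=O)n2CC(O)CSc1ccccc1`: 142 uM
compound 2, `N#Cc1ccc(Cn2c(=O)n(C3OC(CO)[C@@H](O)[C@H]3O)c3nc(N)nc(O)c32)cc1`: 15 uM

In a functional assay (B cells) with Mus musculus as the target (a higher number here means that more compound is needed for the effect, a lower number that less compound is needed), compound 1 gives 142 uM and compound 2 gives 15 uM. Among the compounds with values here, compound 2 therefore holds the lower of the two numbers in this assay, and the only measured step, a 9.5-fold lower number from compound 1 to compound 2 (0.98 log units; beyond the scatter), separates them. That step shows that the arm on the saturated chain carbon bound to an aromatic nitrogen governs the read-out strongly in this small set.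

Compound 3, `NCC(O)Cn1c(=O)n(C2OC(CO)[C@@H](O)[C@H]2O)c2nc(N)nc(O)c21`, has not been measured. It differs from compound 2 as follows: 2-amino-1-hydroxyethyl in place of 4-cyanophenyl on a saturated chain carbon bound to an aromatic nitrogen. Within the data shown here, the one measured step bears on it only indirectly, since it too changed this same arm; it was modest in size. Compound 3 gives up the aromatic ring that compound 2 carries and keeps only a short chain with two donors. On these two numbers alone, the expectation is a move back toward the number of compound 1, estimated as a 6.7-fold higher number from compound 2 to compound 3 (0.82 log units; beyond the scatter). Compound 3 is thus expected to give about 100 uM in this assay, within a range of 30 uM to 330 uM.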

Compound 3, concentration for half-maximal effect: 28 uM
Estimate against measurement, compound 3: 3.6-fold (0.55 log units) above; measured number below the stated range.
By their numbers in this assay, from the lowest: compounds 2 and 3 (each within the scatter of the next); then compound 1.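

In this assay, 2-amino-1-hydroxyethyl in place of 4-cyanophenyl on a saturated chain carbon bound to an aromatic nitrogen gives a 1.9-fold higher number from compound 2 to compound 3 (0.27 log units; within the scatter) and so leaves compound 2 and compound 3 without any order between them. The read-out at this position therefore does not depend on an aromatic ring or a nitrile, since a chain with no ring gives a number that cannot be told apart from that of the 4-cyanobenzyl compound. Amino in place of phenylsulfanyl gives a 5.1-fold lower number from compound 1 to compound 3 (0.71 log units; beyond the scatter), which ties the high number of compound 1 to the phenylsulfanyl group rather than to the hydroxyl-bearing chain that compound 1 and compound 3 share, and nothing at hand explains either step.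

The compounds shown leave open what the amine and the hydroxyl each contribute, as compound 3 carries both on one chain. They also leave open whether a dimethylamino group, a carboxylic acid or a longer chain ending in an amine at this position would stay level with compound 3 or move the number in either direction.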